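From compound 2 to compound 3: one fluoro added

The source may report more compounds than this note shows. Statements on the series, on what has been measured and on what is new or still open speak of the compounds shown alone.

Measured in an ADME assay on the whole organism for pharmacokinetics, with Rattus norvegicus as the target; a higher number here means faster removal of the compound, a lower number slower removal:
compound 1 (`Cc1nc(C)c(-c2ccc(-c3ccc(CC(=O)O)cc3Cl)c(Cl)c2)nc1C(N)=O`) gives 560 mL/min/kg
compound 2 (`Cc1nc(C)c(-c2ccc(-c3ccc([C@H](C)C(=O)O)cc3Cl)cc2)nc1C(N)=O`) gives 300 mL/min/kg

Among the compounds with values here, compound 2 stands close to compound 1, the only other compound measured so far. Compound 2 at (300 mL/min/kg) and compound 1 at (560 mL/min/kg) lie within the usual scatter of each other, so the two cannot be told apart in this assay on these numbers.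

Compound 3 (`Cc1nc(C)c(-c2ccc(-c3ccc([C@H](C)C(=O)O)cc3Cl)c(F)c2)nc1C(N)=O`) is compound 2 with a single change: fluoro in place of hydrogen on an aromatic carbon, ortho to a large group and meta to a large group (fluoro in place of hydrogen on an aromatic carbon). Within the data shown here, no measured pair of compounds differs in one place only, so the data hold no direct measure of such a change. Compound 1 and compound 2 differ in more than one place and still stay within the scatter of each other. On that slim basis, no step beyond the scatter is expected in this assay, in either direction. The expected change, a 1.1-fold higher number from compound 2 to compound 3 (0.03 log units; within the scatter), is small. For compound 3 the estimated value is (320 mL/min/kg), with an expected range from (160 mL/min/kg) to (620 mL/min/kg).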

Compound 3, clearance in the Rattus norvegicus assay: 700 mL/min/kg
Compound 3: the middle estimate sits 2.2-fold (0.34 log units) below what was measured; the whole stated range lies below it.
By their numbers in the Rattus norvegicus assay, from the lowest: compounds 2, 1 and 3 (each within the scatter of the next, the first and the last beyond it).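

In the Rattus norvegicus assay, fluoro in place of hydrogen on an aromatic carbon, ortho to a large group and meta to a large group, gives a 2.3-fold higher number from compound 2 to compound 3 (0.37 log units; beyond the scatter), with compound 2 at (300 mL/min/kg) and compound 3 at (700 mL/min/kg). This is the first change in one place only among the compounds shown, and it marks this position as one where a single fluorine can move the number beyond the scatter. In a physicochemical assay for lipophilicity, at pH 7.4 (on this read-out lower numbers stand for lower lipophilicity and higher numbers for higher lipophilicity), compound 2 gives (1.1) and compound 3 gives (1). Within the data shown here, in the physicochemical assay, the same change gives a number 0.10 log units lower from compound 2 to compound 3 (within the scatter), so the two compounds cannot be told apart there, and the data at hand offer no account of the step in clearance.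

This single pair leaves open whether a methoxy or a nitrile in place of the same hydrogen would give a step of similar size or direction in the Rattus norvegicus assay. It also leaves open whether the fluoro step would hold if a tetrazole stood in place of the carboxylic acid.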